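The compounds below may be only part of what the source reports. "The series", "measured", "known", "first", "only" and "open" are said of these compounds alone.

Measured in a functional assay on SH-SY5Y cells (Homo sapiens) for antagonist activity, read by cAMP accumulation; a higher number here means a more potent compound, by a factor of ten per unit of this negative logarithm, a lower number a less potent compound:
- compound 1 (`CCCCCCOc1ccc(Cc2ccc(NC3=NCCN3)cc2)cc1`): 8.2
- compound 2 (`OCCOc1ccc(Cc2ccc(NC3=NCCN3)cc2)cc1`): 8

Compound 2 at 8 stands within the scatter of compound 1. Compound 3 (`c1cc(NC2=NCCN2)ccc1Cc1ccc(OCC2CCOCC2)cc1`) differs from compound 2 by oxan-4-yl in place of hydroxymethyl on a saturated chain carbon bound to an oxygen on an aromatic ring. Going by the values given here, the only measured step on this chain is a number 0.20 log units lower from compound 1 to compound 2 (within the scatter), so nothing measured points to a change beyond the scatter in this assay. The expected step is a number 0.10 log units higher from compound 2 to compound 3 (within the scatter), which is no expected change beyond the scatter. For compound 3 the estimate is 8.1, with an expected range from 7.6 to 8.6.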

Compound 3, negative logarithm of the antagonist equilibrium constant: 8.5
Beside the measured number, compound 3's estimate is 0.40 log units below it, and the stated range covers the measured number.
By their numbers in this assay, from the lowest: compounds 2, 1 and 3 (each within the scatter of the next, the first and the last beyond it).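

In this assay, going by these compounds alone, the step of a number 0.50 log units higher from compound 2 to compound 3 (beyond the scatter) is the first at this position to clear the scatter, so the group on this saturated chain carbon can shift the number measurably. The step of a number 0.30 log units higher from compound 1 to compound 3 (within the scatter) does not separate oxan-4-yl from the open chain of compound 1, so a six-membered non-aromatic ring is tolerated here. No measurement at hand accounts for either step. Whether the ring oxygen of oxan-4-yl matters remains open, since cyclohexyl is not among these compounds. On these data alone, an amine or a carboxylic acid at this place also remains untested here.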